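The source may hold more compounds than are shown below. What is called first, only, known or untested is meant among the compounds shown, and "the series" means these compounds.

Measured in a functional assay on blood (Homo sapiens), with a stated time of 60 min, in the presence of a further agent that is not named here (a lower number here means that less compound is needed, a higher number that more compound is needed for the effect), each value being a limit of the assay and not a number:

- compound 1 `O=C(Nc1nccs1)C1(S(=O)(=O)c2ccc(Oc3ccc(OC(F)(F)F)cc3)cc2)CCC2(CCNCC2)C1`: > 15000 nM
- compound 2 `CNC(=O)NC(=O)C1(S(=O)(=O)c2ccc(Oc3ccc(OC(F)(F)F)cc3)cc2)CCC2(CCNCC2)C1`: < 400 nM
- compound 3 `CS(=O)(=O)NC(=O)C1(S(=O)(=O)c2ccc(Oc3ccc(OC(F)(F)F)cc3)cc2)CCC2(CCNCC2)C1`: > 15000 nM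

Compound 3 stands at a limit, > 15000 nM, which is the limit of > 15000 nM in this assay, at which 2 of the 3 values shown sit. Compound 4 `Nc1ccc(-c2cccs2)cc1NC(=O)C1(S(=O)(=O)c2ccc(Oc3ccc(OC(F)(F)F)cc3)cc2)CCC2(CCNCC2)C1` has not yet been measured. It carries 2-amino-5-(thiophen-2-yl)phenyl in place of methylsulfonyl on an amide-type nitrogen.

Among the compounds with values here, three measured steps bear on this change, all at the same place. Only methylcarbamoyl stands apart, with an at least 37-fold lower number from compound 1 to compound 2 (1.57 log units; beyond the scatter) and an at least 37-fold higher number from compound 2 to compound 3 (1.57 log units; beyond the scatter), both large. The third is a step that the two limits leave unreadable from compound 1 to compound 3, so neither 1,3-thiazol-2-yl nor methylsulfonyl gives a readable number. Within the data shown here, compound 1, the one measured example with an aromatic ring at this nitrogen, stays at > 15000 nM, so compound 4 is expected to lie near the same limit in this assay, with no clear move in either direction. The expected step is an at least 1.2-fold lower number from compound 3 to compound 4 (0.09 log units; that floor lies within the scatter). For compound 4 the estimate is 12000 nM, with an expected range of 3000 nM to 40000 nM.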

Compound 4, half-maximal effective concentration: 900 nM
Compound 4: the middle estimate sits 13-fold (1.12 log units) above what was measured; the measured number lies below the stated range.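

In this assay, an aromatic ring on the amide-type nitrogen does not by itself leave a compound at the upper limit: 2-amino-5-(thiophen-2-yl)phenyl in place of 1,3-thiazol-2-yl gives an at least 16-fold lower number from compound 1 to compound 4 (1.22 log units; beyond the scatter), and in place of methylsulfonyl it gives an at least 16-fold lower number from compound 3 to compound 4 (1.22 log units; beyond the scatter). Methylcarbamoyl is therefore no longer the only group at this nitrogen that brings a compound clear of that limit, although compound 1 shows that not every aromatic ring does so. Methylcarbamoyl still keeps the lower number, with an at least 2.2-fold higher number from compound 2 to compound 4 (0.35 log units; beyond the scatter).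

The amine and the thiophene ring enter together in compound 4, and the compounds shown do not separate their contributions. On these data alone, how a plain phenyl ring or a 2-aminophenyl group would stand at this nitrogen in this assay remains open.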